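A few compounds are considered here, and "the series" means these few. Any claim that something is new, unique, unknown or untested is made for them only; others in the source may bear on it.

In a functional assay on NALM-6 cells (Homo sapiens) for cytotoxicity, with a stated time of 72 h (on this read-out lower numbers stand for an effect already at smaller amounts and higher numbers for an effect only at larger amounts of compound), the measured compounds read:
- compound 1 `C=C[C@@](C)(/C=C/c1ccc(O)c(C=O)c1)CCC=C(C)C` gives 11200 nM
- compound 2 `C=C[C@@](C)(/C=C/c1ccc(O)c(/C=C/C(=O)c2ccccc2)c1)CCC=C(C)C` gives 4470 nM
- compound 3 `C=C[C@@](C)(/C=C/c1ccc(O)c(/C=C/C#N)c1)CCC=C(C)C` gives > 43400 nM

Compound 3 stands at the limit of > 43400 nM in this assay, at which 1 of the 3 values shown sits, so it has a limit and not a number. Compound 4 `C=C[C@@](C)(/C=C/c1ccc(O)c(/C=C/C(=O)OCC)c1)CCC=C(C)C` keeps the core of compound 3 and differs in one place: ethoxycarbonyl in place of cyano on a double-bonded chain carbon bound to a double-bonded chain carbon.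

Among the compounds with values here, two measured steps bear on this change. The closer one is an at least 9.7-fold higher number from compound 2 to compound 3 (0.98 log units; beyond the scatter), where cyano takes the place of benzoyl at the same carbon. The other is an at least 3.8-fold higher number from compound 1 to compound 3 (0.58 log units; beyond the scatter), where 2-cyanoethenyl takes the place of formyl. Both lie beyond the scatter, and both end at a limit. Compound 2, at 4470 nM, also has a carbonyl group at this place, so a move to a lower number is expected in this assay. Ethoxycarbonyl is not benzoyl, however, so a full return to the level of compound 2 is not expected. The expected change is an at least 3.1-fold lower number from compound 3 to compound 4 (0.49 log units; beyond the scatter), a modest step. For compound 4 the estimated value is 14000 nM, with an expected range from 5000 nM to 40000 nM.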

Compound 4, half-maximal effective concentration: 20900 nM
Estimate against measurement, compound 4: 1.5-fold (0.17 log units) below; low and high end bracket the measured number.
By their numbers in this assay, from the lowest: compound 2; then compounds 1 and 4 (each within the scatter of the next). At a limit, above all of these: compound 3.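

With ethoxycarbonyl in place of cyano at this double-bonded chain carbon, this assay shows an at least 2.0-fold lower number from compound 3 to compound 4 (0.31 log units; beyond the scatter), so among the compounds shown, benzoyl is not the only group at this place that gives a measured number rather than a limit. Compound 3 has only a limit and not a number, so this step gives a minimum and not a full size: the limit of > 43400 nM in this assay, at which 1 of the 4 values shown sits. What is attached to the carbonyl carbon also counts, since ethoxy in place of phenyl gives a 4.7-fold higher number from compound 2 to compound 4 (0.67 log units; beyond the scatter), whereas a 1.9-fold higher number from compound 1 to compound 4 (0.27 log units; within the scatter) lies within the scatter, so 2-(ethoxycarbonyl)ethenyl and formyl on the aromatic carbon cannot be told apart in this read-out.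

On these data alone, how a carboxylic acid, an amide or a longer ester chain at this carbon would read remains open. The compounds shown also leave open whether the carbonyl itself accounts for the difference from cyano, or whether other groups on the carbonyl carbon, such as an amine-bearing chain, would come closer to benzoyl.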